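This account rests on a few compounds, and the source may have more. Where it says the series, first, only, none or still open, it means among the compounds named here.

Within the data shown here, in a functional assay on HeLa cells (Homo sapiens) for antiproliferative activity, read by MTT assay, with a stated time of 48 h (on this read-out lower numbers stand for stronger inhibition and higher numbers for weaker inhibition), compound 1 `c1ccc(-c2nn(-c3ccccc3)cc2-c2nc3ccccc3[nH]2)cc1` gives 1550 nM and compound 2 `FC(F)(F)c1ccc2[nH]c(-c3cn(-c4ccccc4)nc3-c3ccccc3)nc2c1` gives 1920 nM so the only two numbers so far lie within the scatter of each other, and compound 1 stands level with compound 2. Compound 3 `Fc1ccc(-c2nn(-c3ccccc3)cc2-c2nc3ccccc3[nH]2)cc1` is still unmeasured. It is compound 1 with fluoro in place of hydrogen on an aromatic carbon, para to a large group (fluoro in place of hydrogen on an aromatic carbon). Among the measured compounds shown here, one measured step bears on this change, since it too swaps a single hydrogen of the shared core for a substituent (a 1.2-fold higher number from compound 1 to compound 2 (0.09 log units; within the scatter)). That group is trifluoromethyl and not fluoro, so this step is only a rough guide. In this assay no step beyond the scatter is therefore expected, and no direction can be favoured (a 1.0-fold lower number from compound 1 to compound 3 (0.01 log units; within the scatter) as the estimated step). For compound 3 the expected value is 1500 nM with an estimated range from 700 nM to 3200 nM as its limits.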

Compound 3, half-maximal inhibitory concentration: 2330 nM
For compound 3 the middle estimate is 1.6-fold (0.19 log units) below the measured one; measured number inside the range.
By their numbers in this assay, from the lowest: compounds 1, 2 and 3 (each within the scatter of the next).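

In this assay, among these compounds, the swap of phenyl to 4-fluorophenyl gives a 1.5-fold higher number from compound 1 to compound 3 (0.18 log units; within the scatter) and this is the first reading at this position, on a six-membered aromatic ring of carbon only and para to a large group. The earlier step concerned trifluoromethyl at another place on the shared core, whereas this one shows that a single fluoro at this position causes no change that can be told apart from the scatter of repeated measurements. No measurement shown here speaks to why the number behaves in this way. Going by these compounds, whether a larger group at this same position, such as methoxy, an amine or a carboxylic acid, would produce a step beyond the scatter stays open. Also open, on these data alone, is how fluoro would behave on another carbon of this ring.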